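Benzyl in Place of tert-Butyl: Expected Step

This account rests on a few compounds, and the source may have more. Where it says the series, first, only, none or still open, it means among the compounds named here.

Compound 2 `CC1=C(C(=O)OC(C)(C)C)C(c2cccs2)NC(=O)N1C` gives 22% in an assay on membranes from HeLa cells for displacement of a labelled ligand from adenosine receptor A3 (Homo sapiens), read by scintillation counting, with a stated time of 180 min, tested at 1 uM; a higher number here means more inhibition at the concentration tested (going by the name of the read-out), a lower number less inhibition. Among the compounds with values here, only one other number exists for comparison: compound 1 `CC1=C(C(=O)OC(C)C)C(c2cccs2)NC(=O)N1C` gives 17% in this assay, and the two values sit within the scatter of each other, so neither number can be called the higher. Within the data shown here, the one measured step, a number 5 percentage points higher from compound 1 to compound 2 (within the scatter), which puts a methyl in place of hydrogen on a saturated chain carbon bound to an oxygen next to a carbonyl group and two saturated chain carbons, moved the number only within the scatter.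

Compound 3 `CC1=C(C(=O)OCc2ccccc2)C(c2cccs2)NC(=O)N1C` differs from compound 2 by benzyl in place of tert-butyl on an oxygen next to a carbonyl group. Among the measured compounds shown here, no measured step tests a change of this kind; the only step available, from compound 1 to compound 2, concerns a small extension at the same oxygen and was within the scatter, so it gives no direction for a larger replacement. Compound 3 is therefore expected to give about 22% in this assay, within 5% to 45%. The expected step of no change at the digits printed from compound 2 to compound 3 (within the scatter) is estimated to lie within the scatter, with wide uncertainty.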

Compound 3, a percentage reported as inhibition, at one concentration (the size of the read-out at that concentration, not a potency): 18%
Compound 3: middle estimate off by 4 percentage points, on the high side; the range from low to high includes it.
By their numbers in this assay, from the lowest: compounds 1, 3 and 2 (each within the scatter of the next).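

In this assay, benzyl in place of tert-butyl on an oxygen next to a carbonyl group gives a number 4 percentage points lower from compound 2 to compound 3 (within the scatter), and benzyl in place of isopropyl at the same oxygen gives a number 1 percentage points higher from compound 1 to compound 3 (within the scatter). Within the data shown here, the earlier pair compared only two groups without a ring, whereas these steps bring in one six-membered aromatic ring of carbon only and a group of 7 heavy atoms, and all three compounds still lie within the scatter of each other, so neither the ring nor the larger group separates them in this read-out at this position. No measurement shown here bears on why these numbers lie so close together.

On these data alone, it remains open whether a group of a different kind on this oxygen, such as a longer chain ending in an amine or a carboxylic acid, would move the number beyond the scatter. Since each compound is described by a percentage at a single concentration, the numbers also leave open how the three compare in potency.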